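Three nitrobenzyl amines and a carboxamide that awaits its read-out

The source may hold more compounds than are shown below. What is called first, only, known or untested is meant among the compounds shown, and "the series" means these compounds.

Three compounds share a core in which a substituted benzyl amine is attached to a trifluoromethyl-bearing indazole. Compound 1 `O=[N+]([O-])c1ccccc1CNc1cc(C(F)(F)F)cc2[nH]ncc12` carries the nitro group on one aromatic carbon of the benzyl ring, compound 2 `O=[N+]([O-])c1cccc(CNc2cc(C(F)(F)F)cc3[nH]ncc23)c1` on another, and compound 3 `CS(=O)(=O)c1ccc(CNc2cc(C(F)(F)F)cc3[nH]ncc23)c([N+](=O)O)c1` adds a methylsulfonyl group to the nitro-bearing ring. In an assay for inhibition of Indoleamine 2,3-dioxygenase 1 (Homo sapiens), with stated times of 10 min and 60 min, tested at 10 uM (on this read-out lower numbers stand for a weaker effect and higher numbers for a stronger effect at the one concentration tested), compound 1 gives 35%, compound 2 gives 45% and compound 3 gives 63%. Compound 2 thus stands second highest of the three; its value lies within the scatter of that of compound 1, so no order between the two can be read, while compound 3 sits beyond the scatter above it.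

Compound 4 `CNC(=O)c1cccc(CNc2cc(C(F)(F)F)cc3[nH]ncc23)c1` has not yet been measured. Relative to compound 2 it differs as follows: methylcarbamoyl in place of nitro on an aromatic carbon. Among the measured compounds shown here, no pair among the measured compounds shows this exchange, so the account rests on compound 2 alone. The step of a number 5 percentage points lower from compound 2 to compound 4 (within the scatter) is expected to be small, with no change beyond the scatter in either direction. Compound 4 is therefore expected to give about 40% in this assay, with a range from 15% to 65%.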

Compound 4, a percentage reported as inhibition, at one concentration (the size of the read-out at that concentration, not a potency): 33%
The estimate for compound 4 lay 7 percentage points above the measured number; the range from low to high includes it.
By their numbers in this assay, from the lowest: compounds 4, 1 and 2 (each within the scatter of the next, the first and the last beyond it); then compound 3.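

Methylcarbamoyl in place of nitro on an aromatic carbon, meta to a large group, gives a number 12 percentage points lower from compound 2 to compound 4 (beyond the scatter) in this assay. Among the compounds shown here, this is the first single exchange in the set, and it shows that the read-out responds to what this place carries. The effect does not vanish with the nitro group: compound 4 still gives 33% at the one concentration tested, so nitro is not needed at this place for some effect, although no reason for the step can be offered from what is available.

The compounds shown leave open whether the lower number follows from the loss of nitro or from the entry of methylcarbamoyl, which brings a hydrogen-bond donor that nitro lacks, and a nitrile, a carboxylic acid or an unsubstituted carboxamide at this place could help separate the two. They also leave open whether the same exchange would give a step of like size elsewhere on the benzyl ring, or on a ring that also carries methylsulfonyl, and how the step would look as a potency rather than at one concentration.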